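Swapping an ethyl for a pyrrole ring: expected lipophilicity

The source may report more compounds than this note shows. Statements on the series, on what has been measured and on what is new or still open speak of the compounds shown alone.

Measured compounds:
compound 1, `CN1CCN(CCCS(=O)(=O)c2ccc3nc(NC(=O)NC(=O)c4ccccc4Cl)sc3c2)CC1`, 1.8
compound 2, `CN1CCN(CCCS(=O)(=O)c2ccc3nc(NC(=O)NC(=O)c4cc(-n5cccn5)ccc4Cl)sc3c2)CC1`, 2
compound 3, `CCc1ccc(Cl)c(C(=O)NC(=O)Nc2nc3ccc(S(=O)(=O)CCCN4CCN(C)CC4)cc3s2)c1`, 2.9

In a physicochemical assay for lipophilicity (a lower number here means a more polar compound, a higher number a more lipophilic compound), compound 3 stands highest of the three, with compound 2 nearest and compound 1 furthest. Compound 4 is `CN1CCN(CCCS(=O)(=O)c2ccc3nc(NC(=O)NC(=O)c4cc(-n5cccc5)ccc4Cl)sc3c2)CC1`, not yet measured. The change is 1H-pyrrol-1-yl in place of ethyl on an aromatic carbon. Among the compounds with values here, two measured steps bear on it. The step of a number 1.10 log units higher from compound 1 to compound 3 (beyond the scatter) shows ethyl in place of hydrogen giving a large rise, while a number 0.20 log units higher from compound 1 to compound 2 (within the scatter) shows a pyrazol-1-yl ring in place of hydrogen giving a rise within the scatter; together, a number 0.90 log units higher from compound 2 to compound 3 (beyond the scatter). A pyrrol-1-yl ring is closest in kind to the pyrazol-1-yl ring, so a fall in this assay is expected for compound 4, somewhat smaller than the step from compound 3 to compound 2, estimated as a number 0.60 log units lower from compound 3 to compound 4 (beyond the scatter). Compound 4 is therefore estimated at 2.3, between 1.9 and 2.7.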

Compound 4, distribution coefficient: 2.6
Beside the measured number, compound 4's estimate is 0.30 log units below it; measured number inside the range.
By their numbers in this assay, from the lowest: compounds 1 and 2 (each within the scatter of the next); then compounds 4 and 3 (each within the scatter of the next).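

In this assay the 1H-pyrrol-1-yl ring and ethyl cannot be told apart on this aromatic carbon, with a number 0.30 log units lower from compound 3 to compound 4 (within the scatter) as their step. Having a five-membered aromatic ring here does not settle the number: swapping one such ring for the other gives a number 0.60 log units higher from compound 2 to compound 4 (beyond the scatter) as a step beyond the scatter, and replacing hydrogen gives a number 0.80 log units higher from compound 1 to compound 4 (beyond the scatter) as a step, whereas the 1H-pyrazol-1-yl ring stayed within the scatter of hydrogen. Nothing available explains why the two rings differ.

Open, on these data alone, is where an amine, a carboxylic acid or a longer chain on this carbon would fall in this assay relative to these compounds. Also open, as far as these compounds go, is whether the gap between the two rings would hold on a different core.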